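A few compounds are considered here, and "the series" means these few. Any claim that something is new, unique, unknown or untested is made for them only; others in the source may bear on it.

The series starts from compound 1 `Cc1nc(-c2ccccc2)n2c(O)nncc12` and compound 2 `C=CCSc1nncc2c(C)nc(C)n12`, both tested in a functional assay for inhibition, with Homo sapiens as the target; a higher number here means a weaker inhibitor, a lower number a stronger inhibitor. For compound 1 the assay reports only a limit, > 48000 nM, and not a number. For the measured compounds named here, compound 2 is the one compound here with a measured number: in this assay compound 2 gives 59000 nM, a weak inhibition. The only other result in the set belongs to compound 1 and is a limit (the limit of > 48000 nM in this assay, at which 1 of the 2 values shown sits). Compound 3 `C=CCSc1nncc2c(C)nc(-c3ccccc3)n12` is not yet measured. Compound 3 differs from compound 2 by one change (phenyl in place of methyl on an aromatic carbon), phenyl in place of methyl on an aromatic carbon, on the five-membered aromatic ring with two nitrogen atoms, between two ring nitrogen atoms, two ring bonds from the ring atom that bears a methyl group. Going by the values given here, compound 1 carries the same phenyl at that place and reaches only the limit, so the phenyl has not yet been seen to bring potency on this core. The step expected from compound 2 to compound 3 is therefore small, a 1.1-fold lower number from compound 2 to compound 3 (0.03 log units; within the scatter), within the scatter in either direction. Compound 3 is estimated to give 55000 nM in this assay, with a range from 15000 nM to 200000 nM.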

Compound 3, half-maximal inhibitory concentration: > 48000 nM
Compound 3 ended at the assay's limit; the forecaster's own chance of this, stated with the estimate: 45%; the middle value does not contradict the limit.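

In this assay compound 3 gives > 48000 nM, which is a limit and not a number, so the steps from compound 2 and from compound 1 to compound 3 cannot be read. The compounds shown leave open whether phenyl in place of methyl, or allylsulfanyl in place of hydroxy, changes the inhibition at all on the shared core.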